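The compounds below may be only part of what the source reports. "The series", "measured", "known", "first", "only" and "open" are said of these compounds alone.

In a functional assay on M14 cells (Homo sapiens) for inhibition, read by sulforhodamine B assay, with a stated time of 48 h (on this read-out lower numbers stand for higher toxicity in this test and higher numbers for lower toxicity in this test), compound 1 `COc1cc(-c2nn(-c3cccc(NC(=O)Nc4cc(C(F)(F)F)cc(C(F)(F)F)c4)c3)cc2-c2ccncc2)ccc1Cl` gives only a limit of the assay, > 50000 nM, not a number. Compound 2 `O=C(Nc1cccc(-n2cc(-c3ccncc3)c(-c3ccc(Cl)c(O)c3)n2)c1)Nc1cc(C(F)(F)F)cc(C(F)(F)F)c1` carries hydrogen in place of methyl on an oxygen on an aromatic ring and gives 6060 nM in this assay, which is an at least 8.2-fold lower number from compound 1 to compound 2 (0.91 log units; beyond the scatter). Compound 3 `COc1cc(-c2nn(-c3cccc(NC(=O)Nc4ccc(Cl)c(C(F)(F)F)c4)c3)cc2-c2ccncc2)ccc1Cl` gives 19100 nM in this assay; the difference between the core of compound 3 and the core of compound 1 is not broken down here. Compound 4 `O=C(Nc1cccc(-n2cc(-c3ccncc3)c(-c3ccc(Cl)c(O)c3)n2)c1)Nc1ccc(Cl)c(C(F)(F)F)c1` has not yet been measured and differs from compound 3 by hydrogen in place of methyl on an oxygen on an aromatic ring, the same kind of change, at a place described in the same words. The earlier step is known only as a bound, because compound 1 sits at the limit of > 50000 nM in this assay, at which 1 of the 3 values shown sits. A smaller shift is therefore expected this time. Compound 4 is expected to give 4500 nM in this assay, an estimated step of a 4.2-fold lower number from compound 3 to compound 4 (0.63 log units; beyond the scatter).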

Compound 4, concentration lethal to 50% of the cells: > 32500 nM
Compound 4 gave a limit, no number (the forecaster's own chance of this, stated with the estimate: 3%); middle value at least 7.2-fold (0.85 log units) away from the limit.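

In this assay compound 4 gives only a limit of the assay, > 32500 nM, not a number. Going from methoxy to hydroxy here gives an at least 1.7-fold higher number from compound 3 to compound 4 (0.23 log units; that floor lies within the scatter), so the drop in the number seen on the core of compound 1 does not carry over to the core of compound 3, and the two steps differ: the same change on two cores in this assay, an at least 8.2-fold lower number (0.91 log units; beyond the scatter) from compound 1 to compound 2 and an at least 1.7-fold higher number (0.23 log units; that floor lies within the scatter) from compound 3 to compound 4, at least 14-fold (1.14 log units) apart, beyond the scatter of two such steps Each step has one end at a limit, so the true size of neither is known, and these two pairs do not show why the change behaves differently on the two cores.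

The compounds shown leave open which way the same change would go on any further core. They also leave open how an amine or a carboxylic acid in place of the hydroxy group, or a longer chain on the oxygen such as ethoxy, would read in this assay.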